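Hydroxyphenyl position swap on a trifluoromethoxy-bearing pyridine core

This account rests on a few compounds, and the source may have more. Where it says the series, first, only, none or still open, it means among the compounds named here.

Compound 1 `Oc1cccc(-c2cc(-c3ccccc3C(F)(F)F)cc(-c3ccccc3O)n2)c1` and compound 2 `Oc1ccc(-c2cc(-c3ccccc3C(F)(F)F)cc(-c3ccccc3O)n2)cc1` share one core; compound 3 `Oc1cccc(-c2cc(-c3ccc(OC(F)(F)F)cc3)cc(-c3ccccc3O)n2)c1` and compound 4 `Oc1ccc(-c2cc(-c3ccc(OC(F)(F)F)cc3)cc(-c3ccccc3O)n2)cc1` share another, and the difference between the two cores is not broken down here. In a functional assay on DU-145 cells (Homo sapiens) for inhibition (a lower number here means a stronger inhibitor, a higher number a weaker inhibitor), compound 1 gives 7250 nM, compound 2 gives 6690 nM and compound 3 gives 21100 nM. The change 4-hydroxyphenyl in place of 3-hydroxyphenyl on an aromatic carbon produced a 1.1-fold lower number from compound 1 to compound 2 (0.03 log units; within the scatter), so the two hydroxyphenyl isomers on that core are indistinguishable at this level of scatter. The change to compound 4 is 4-hydroxyphenyl in place of 3-hydroxyphenyl on an aromatic carbon, the same kind of change, though the surroundings differ: on the first core the site is meta to a 2-(trifluoromethyl)phenyl group and meta to a 2-hydroxyphenyl group, on the second it is meta to a 2-hydroxyphenyl group and meta to a large group. Among the compounds with values here, with only one earlier instance, the expectation rests on that step alone. Compound 4 is expected at 19000 nM, a step of a 1.1-fold lower number from compound 3 to compound 4 (0.05 log units; within the scatter), with a range of 9000 nM to 40000 nM, because a 1.1-fold lower number from compound 1 to compound 2 (0.03 log units; within the scatter) suggests the position of the hydroxyl on this ring hardly moves the result.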

Compound 4, half-maximal inhibitory concentration: > 50000 nM
Compound 4: a limit, no number; the forecaster's own chance of this, stated with the estimate: 5%; middle value at least 2.6-fold (0.42 log units) away from the limit.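

In this assay compound 4 gives > 50000 nM, which is a limit of the assay and not a number. On this core, 4-hydroxyphenyl in place of 3-hydroxyphenyl gives an at least 2.3-fold higher number from compound 3 to compound 4 (0.37 log units; beyond the scatter), so the swap registers here as a loss of inhibition, with only its lower bound known. Carrying the change from one core to another is therefore neither shown to hold nor shown to fail, since the limit leaves the true size of this step unknown and the two steps cannot be separated: the same change on two cores in this assay, a 1.1-fold lower number (0.03 log units; within the scatter) from compound 1 to compound 2 and an at least 2.3-fold higher number (0.37 log units; beyond the scatter) from compound 3 to compound 4; the limit leaves it open whether they differ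

Still open, going by these compounds, is how far the step on the core of compound 3 really extends, which would need a value for compound 4 rather than a limit, and whether a second pair on either core would behave as these two do. Also open, on these data alone, is how an amine or a carboxylic acid in place of the hydroxyl on this ring would read on either core.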